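A few compounds are considered here, and "the series" means these few. Any claim that something is new, unique, unknown or untested is made for them only; others in the source may bear on it.

Three compounds with a shared core are followed here in a functional assay on the whole organism with Rattus norvegicus as the target; on this read-out higher numbers stand for an effect only at larger amounts of compound and lower numbers for an effect already at smaller amounts. Compound 1 `CSc1cc(C)nc(SC)c1NC(=O)N(Cc1ccccc1)Cc1ccc(Oc2ccc(F)cc2)cc1` reads < 0.01 mg/kg, which is a limit of the assay and not a number. Among the measured compounds shown here, compound 2 `CSc1cc(C)nc(SC)c1NC(=O)N(Cc1ccc(Oc2ccc(Br)cc2)cc1)C1CCCCCC1` gives 0.02 mg/kg, the only actual number so far, so its standing cannot yet be judged against a second measured value. Compound 3 `CSc1cc(C)nc(SC)c1NC(=O)N(Cc1ccccc1)Cc1ccc(Oc2ccc(Br)cc2)cc1` keeps everything in compound 2 except one group, with benzyl in place of cycloheptyl on an amide-type nitrogen.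

For the measured compounds named here, no measured pair shows this swap on its own, so any expectation is indirect. Although it differs from compound 3 elsewhere in the molecule, compound 1 already carries benzyl on that nitrogen, and compound 1 reads < 0.01 mg/kg, again a limit. A small shift toward smaller doses therefore seems likely. The estimated change a 2.0-fold lower number from compound 2 to compound 3 (0.30 log units; within the scatter) is modest and is expected to stay about within the usual scatter. Compound 3 may itself be expected to land at the limit of < 0.01 mg/kg in this assay, at which 1 of the 2 values shown sits. For compound 3 the estimated dose is 0.01 mg/kg, with an expected range from 0.003 mg/kg to 0.04 mg/kg.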

Compound 3, dose for half-maximal effect: 0.011 mg/kg
Compound 3: middle estimate off by 1.1-fold (0.04 log units), on the low side; the range from low to high includes it.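

Among the compounds shown here, compound 2 and compound 3 give the first reading of a single change on the amide-type nitrogen, where a seven-membered non-aromatic ring gives way to a six-membered aromatic ring of the same heavy-atom count, and in this assay this swap stays small: a 1.8-fold lower number from compound 2 to compound 3 (0.26 log units; within the scatter). The value of compound 1, < 0.01 mg/kg, is a limit of the assay and not a number. The other change, bromo in place of fluoro on an aromatic carbon, can therefore be read only as a floor, and that floor does not rise beyond the usual scatter: an at least 1.1-fold higher number from compound 1 to compound 3 (0.04 log units; that floor lies within the scatter).

As far as these compounds go, with doses this small, the values stand close to the end of what the read-out can report, so any real difference between these compounds may be hard to see: the limit of < 0.01 mg/kg in this assay, at which 1 of the 3 values shown sits. It remains open how the dose would respond on that same nitrogen to a longer chain such as hexyl, or to a benzyl group carrying an amine or a carboxylic acid, and the same holds for chloro in place of bromo on the aromatic carbon.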